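Swapping an amide for a sulfonamide on the chain of compound 2

The compounds below may be only part of what the source reports. "The series", "measured", "known", "first", "only" and "open" are said of these compounds alone.

Measured compounds:
Compound 1, `Cc1nc(N(C)C2CCCC2)nc2ccc(NC(=O)/C=C/c3ccc(Cl)cc3)cc12`: 57 nM
Compound 2, `Cc1nc(NCCNC(=O)C2CC2)nc2ccc(NC(=O)/C=C/c3ccc(OC(F)(F)F)cc3)cc12`: 23 nM

Of the compounds shown here, two have been tested in a functional assay on CHO-K1 cells for antagonist activity at melanin-concentrating hormone receptor 1 (Homo sapiens), read by inositol phosphate accumulation, with stated times of 10 min and 45 min; a lower number here means a stronger inhibitor, a higher number a weaker inhibitor. Compound 1 gives 57 nM. Compound 2 gives 23 nM, which is the lower of the two numbers, and the gap between them lies beyond the usual scatter. Compound 2 therefore stands as the stronger inhibitor of the pair on the numbers available. The two differ in more than one place, so nothing is said here about which part of the structure accounts for the gap.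

Compound 3, `Cc1nc(NCCNS(C)(=O)=O)nc2ccc(NC(=O)/C=C/c3ccc(OC(F)(F)F)cc3)cc12`, has not yet been measured. It keeps the whole of compound 2 apart from one change: methylsulfonyl in place of cyclopropylcarbonyl on an amine nitrogen. The rest of the molecule, including the shared core and the cinnamamide bearing the trifluoromethoxy group, is unchanged.

Among the measured compounds shown here, no single-site step between measured compounds is available to guide the expectation, so the estimate rests on compound 2 alone. In this assay compound 3 is expected to show a step of a 1.5-fold higher number from compound 2 to compound 3 (0.18 log units; within the scatter), that is, a number not clearly beyond the scatter from compound 2. The estimate for compound 3 in this assay is 35 nM, within a range of 10 nM to 120 nM.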

Compound 3, half-maximal inhibitory concentration: 142 nM
For compound 3 the middle estimate is 4.1-fold (0.61 log units) below the measured one; measured number outside the range, above it.
By their numbers in this assay, from the lowest: compound 2; then compound 1; then compound 3.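

In this assay, among the compounds shown here, putting methylsulfonyl in place of cyclopropylcarbonyl on an amine nitrogen gives a 6.2-fold higher number from compound 2 to compound 3 (0.79 log units; beyond the scatter), so this is the first change that can be read at a single site. Compound 1 and compound 2 differ in more than one place and could say nothing about any one part of the structure, whereas this pair shows that the number responds to what sits on this nitrogen while the shared core and the cinnamamide bearing the trifluoromethoxy group stay the same. Nothing measured here speaks to the reason for the step, which therefore stands as an observation only.

This one swap alters both the ring and the linking group together, so the compounds shown do not separate the departure of the cyclopropyl ring from the replacement of carbonyl by sulfonyl, which an acetyl or a cyclopropylsulfonyl group on the same nitrogen could pull apart. They also leave open how a free amine, a urea or a longer chain at this place would compare with the cyclopropylcarbonyl of compound 2.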